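A few compounds are considered here, and "the series" means these few. Any claim that something is new, unique, unknown or untested is made for them only; others in the source may bear on it.

Three compounds share one core and differ only in the group carried on the outer aromatic ring. Compound 1 `CCOc1ccc(-c2ccc(N(C[C@@H](N)[C@@H](C)CC)C(=O)[C@@H]3C[C@H]3c3ccccc3)cc2)cc1` carries an ethoxy there, and in a functional assay for agonist activity at G protein-coupled receptor 88 (Homo sapiens), read by HTRF and cAMP accumulation (on this read-out lower numbers stand for an effect already at smaller amounts and higher numbers for an effect only at larger amounts of compound), compound 1 gives 90 nM. Compound 2 `CC[C@H](C)[C@H](N)CN(C(=O)[C@@H]1C[C@H]1c1ccccc1)c1ccc(-c2ccc(COC)cc2)cc1` carries a methoxymethyl instead, and in this assay compound 2 gives 35 nM. Compound 3 `CC[C@H](C)[C@H](N)CN(C(=O)[C@@H]1C[C@H]1c1ccccc1)c1ccc(-c2ccc(CCC(=O)OC)cc2)cc1` carries a 2-(methoxycarbonyl)ethyl, and in this assay compound 3 gives 110 nM. Compound 3 thus sits at the high end of the three numbers: the step of a 1.2-fold higher number from compound 1 to compound 3 (0.09 log units; within the scatter) stays within the scatter, whereas the step of a 3.1-fold higher number from compound 2 to compound 3 (0.50 log units; beyond the scatter) lies beyond it, and the step of a 2.6-fold lower number from compound 1 to compound 2 (0.41 log units; beyond the scatter) is of a similar modest size.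

Compound 4 `CC[C@H](C)[C@H](N)CN(C(=O)[C@@H]1C[C@H]1c1ccccc1)c1ccc(-c2ccc(NC(C)=O)cc2)cc1` is the next member of the set. The change from compound 3 is acetamido in place of 2-(methoxycarbonyl)ethyl on an aromatic carbon. For the measured compounds named here, no measured step brings in a group of this kind, so there is no direct precedent. What the three measured steps do show is that exchanging one group for another at this position shifts the number only by modest amounts, sometimes up and sometimes down. On that basis the step of a 1.4-fold lower number from compound 3 to compound 4 (0.14 log units; within the scatter) is expected to be small, with its direction uncertain. Compound 4 is therefore estimated to give about 80 nM in this assay, with a range from 25 nM to 250 nM.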

Compound 4, half-maximal effective concentration: 5500 nM
For compound 4 the middle estimate is 69-fold (1.84 log units) below the measured one; measured number outside the range, above it.
By their numbers in this assay, from the lowest: compound 2; then compounds 1 and 3 (each within the scatter of the next); then compound 4.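

In this assay, for the compounds shown here, this position turns out to be far less forgiving than the earlier compounds suggested: ethoxy, methoxymethyl and 2-(methoxycarbonyl)ethyl differ from one another by modest steps at most, whereas acetamido brings a 50-fold higher number from compound 3 to compound 4 (1.70 log units; beyond the scatter), as well as a 160-fold higher number from compound 2 to compound 4 (2.20 log units; beyond the scatter) and a 61-fold higher number from compound 1 to compound 4 (1.79 log units; beyond the scatter). So the position does respond strongly to the group it carries, and a para group on the outer ring can cost a great deal even though the rest of the molecule stays the same. In the change from compound 3 to compound 4, a hydrogen-bond donor and a nitrogen enter while the heavy-atom count falls, but these differences arrive together, and nothing available here shows which of them, if any, lies behind the large step.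

The compounds shown leave open whether the amide hydrogen itself matters, which an N-methylacetamido group at the same place could help to separate from the rest of the change. They also leave open how a plain amine, a carboxylic acid or a longer amide chain on this aromatic carbon would compare with acetamido and with the three better-tolerated groups.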